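A few compounds are considered here, and "the series" means these few. Any claim that something is new, unique, unknown or untested is made for them only; others in the source may bear on it.

Among the compounds with values here, compound 1 `N#Cc1ccn2c(-c3ccccc3)c(-c3ccccc3)c(Cc3ccccc3)c2c1` is the only member of this set with a number. In an assay for inhibition of Polyunsaturated fatty acid lipoxygenase ALOX15 (Oryctolagus cuniculus) (a higher number here means a weaker inhibitor, a lower number a stronger inhibitor), compound 1 gives 46000 nM, a weak result. Compound 2 `COc1ccc(C(=O)Oc2c(-c3ccccc3)c(-c3ccccc3)n3ccc(C#N)cc23)cc1` has no single number: in this assay compound 2 gives "not determined" (no result reported). The same is true of compound 3 `CC(O)c1c(-c2ccccc2)c(-c2ccccc2)n2ccc(C#N)cc12`, for which in this assay compound 3 gives "not determined" (no result reported). Compound 4 `N#Cc1ccn2c(-c3ccccc3)c(-c3ccccc3)c(C(=O)c3ccccc3)c2c1` differs from compound 2 by benzoyl in place of ((4-methoxyphenyl)carbonyl)oxy on an aromatic carbon. Within the data shown here, with no step between measured compounds to lean on, the size and direction of the change from compound 2 to compound 4 in this assay cannot be judged from the numbers at hand. Compound 4 is expected to remain a weak inhibitor in this assay, near 30000 nM with a range from 8000 nM to 150000 nM, because its close relative compound 1 gives 46000 nM.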

Compound 4, half-maximal inhibitory concentration: 43000 nM
Compound 4: the middle estimate sits 1.4-fold (0.16 log units) below what was measured; measured number inside the range.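

In this assay, within the data shown here, the change at this position, benzoyl in place of benzyl on an aromatic carbon (a 1.1-fold lower number from compound 1 to compound 4 (0.03 log units; within the scatter)), gives the first step that can be read in this set. The carbonyl between the shared core and the phenyl ring thus leaves the result unmoved here, and both compounds remain weak inhibitors. Nothing measured here gives a reason for this.

Going by these compounds, whether an amine, a carboxylic acid or a longer chain at this position would shift the number stays open. Steps to compound 2 and compound 3 cannot be read.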